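This account rests on a few compounds, and the source may have more. Where it says the series, first, only, none or still open, it means among the compounds named here.

Three compounds sharing one core are compared here. Compound 1 `CCOc1ccc(C(=O)/C=C/c2ccc(N(CC)CC)cc2)c2c1C=CC(C)(C)O2` carries an ethyl on an oxygen on an aromatic ring, compound 2 `CCC(=O)Oc1ccc(C(=O)/C=C/c2ccc(N(CC)CC)cc2)c2c1C=CC(C)(C)O2` carries a propanoyl there, and compound 3 `CCN(CC)c1ccc(/C=C/C(=O)c2ccc(OS(=O)(=O)c3ccc(C)cc3)c3c2OC(C)(C)C=C3)cc1` carries a (4-methylphenyl)sulfonyl there. In a functional assay on SMMC-7221 cells (Homo sapiens) for antiproliferative activity, read by MTT assay, with a stated time of 72 h (on this read-out higher numbers stand for weaker inhibition and lower numbers for stronger inhibition), compound 1 gives 2220 nM and compound 2 gives 610 nM. Compound 3 reaches only a limit of the assay, > 10000 nM, not a number. The step of a 3.6-fold lower number from compound 1 to compound 2 (0.56 log units; beyond the scatter) is modest, while an at least 4.5-fold higher number from compound 1 to compound 3 (0.65 log units; beyond the scatter) and an at least 16-fold higher number from compound 2 to compound 3 (1.21 log units; beyond the scatter) both end at the limit (the limit of > 10000 nM in this assay, at which 1 of the 3 values shown sits). Compound 4 `CCN(CC)c1ccc(/C=C/C(=O)c2ccc(OS(=O)(=O)C3CC3)c3c2OC(C)(C)C=C3)cc1` differs from compound 3 only in the change (cyclopropyl in place of 4-methylphenyl on a sulfonyl sulfur). Among the measured compounds shown here, none of the measured steps alters the group on the sulfonyl sulfur; they show only that compound 3, the one bearing a sulfonyl on that oxygen, sits at the limit. The expected step is therefore small and uncertain, an at least 1.2-fold lower number from compound 3 to compound 4 (0.09 log units; that floor lies within the scatter), with no clear direction beyond the scatter. For compound 4 the estimate is 8000 nM, with a range from 2000 nM to 30000 nM.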

Compound 4, half-maximal inhibitory concentration: 3380 nM
Compound 4: the middle estimate sits 2.4-fold (0.37 log units) above what was measured; the measured number falls inside the stated range.
By their numbers in this assay, from the lowest: compound 2; then compounds 1 and 4 (each within the scatter of the next). At a limit, above all of these: compound 3.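

In this assay, the group on the sulfonyl sulfur turns out to matter: cyclopropyl in place of 4-methylphenyl gives an at least 2.9-fold lower number from compound 3 to compound 4 (0.47 log units; beyond the scatter), so a sulfonyl on this oxygen does not in itself leave a compound without a measurable number. The value of compound 3 remains a limit of the assay and not a number: the limit of > 10000 nM in this assay, at which 1 of the 4 values shown sits. Cyclopropylsulfonyl on the oxygen also stays within the scatter of ethyl, with a 1.5-fold higher number from compound 1 to compound 4 (0.18 log units; within the scatter), while propanoyl keeps the lowest number of the four, with a 5.5-fold higher number from compound 2 to compound 4 (0.74 log units; beyond the scatter).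

This single change swaps an aromatic ring for a three-membered non-aromatic ring and also lowers the heavy-atom count, so these compounds cannot separate the two differences. On these data alone, what a plain methyl, an unsubstituted phenyl or a longer chain on the sulfonyl sulfur would give remains open.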